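Swapping Halogens on the Aryl Ring of Compound 2

The compounds below may be only part of what the source reports. "The series", "measured", "known", "first", "only" and "open" are said of these compounds alone.

Compound 2 `Cc1c(C(=O)/C=C/c2ccc(Cl)c(Cl)c2)[n+]([O-])c2ccccc2[n+]1[O-]` has the highest number of the three measured compounds in a functional assay on HL-60 cells (Homo sapiens) for cytotoxicity, with a stated time of 48 h; a lower number here means that less compound is tolerated, a higher number that more compound is tolerated: compound 2 gives 27000 nM. Compound 1 `COc1ccc(/C=C/C(=O)c2c(C)[n+]([O-])c3ccccc3[n+]2[O-])cc1OC` gives 14000 nM, a value within the scatter of compound 2, while compound 3 `COc1cc(/C=C/C(=O)c2c(C)[n+]([O-])c3ccccc3[n+]2[O-])cc(OC)c1OC` gives 1900 nM, clearly lower. For the measured compounds named here, the only step between single-change neighbours, a 7.4-fold lower number from compound 1 to compound 3 (0.87 log units; beyond the scatter), concerns an added methoxy on the aromatic ring and does not touch a halogen. Compound 4 `Cc1c(C(=O)/C=C/c2ccc(Br)cc2)[n+]([O-])c2ccccc2[n+]1[O-]` differs from compound 2 by 4-bromophenyl in place of 3,4-dichlorophenyl on a double-bonded chain carbon bound to a double-bonded chain carbon. Going by the values given here, no measured step bears on a halogen swap of this kind, so no step beyond the scatter is expected. Compound 4 is expected to give 20000 nM, between 7000 nM and 60000 nM. The estimated step of a 1.4-fold lower number from compound 2 to compound 4 (0.13 log units; within the scatter) is therefore small.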

Compound 4, half-maximal cytotoxic concentration: 23000 nM
Estimate against measurement, compound 4: 1.2-fold (0.06 log units) below; low and high end bracket the measured number.
By their numbers in this assay, from the lowest: compound 3; then compounds 1, 4 and 2 (each within the scatter of the next).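

In this assay the exchange of 3,4-dichlorophenyl for 4-bromophenyl gives a 1.2-fold lower number from compound 2 to compound 4 (0.07 log units; within the scatter) and so stays within the usual scatter, which shows that this aryl group can change its halogens without a clear shift in the number. The step alters the kind and the count of halogen together, so it cannot separate the two. Nothing available explains why the step is this small.

Still open, on these data alone, is what a 4-fluorophenyl group or a 4-aminophenyl group would give at this place, and whether a single chlorine alone would behave like the bromine.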